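Working notes: compound 2 to compound 3

The compounds below may be only part of what the source reports. "The series", "measured", "known", "first", "only" and "open" are said of these compounds alone.

For the measured compounds named here, compound 2 `COc1cc(C(OC(C)=O)c2ccc3c(ccn3C)c2)cc(OC)c1OC` gives 6.4 nM in a functional assay on HeLa cells (Homo sapiens) for cytotoxicity, read by XTT assay, with a stated time of 72 h (on this read-out lower numbers stand for stronger inhibition and higher numbers for weaker inhibition), and holds the only actual number in this small set. Compound 1 `CCn1ccc2cc(C(O)c3cc(OC)c(OC)c(OC)c3)ccc21` gives > 1000 nM in this assay and this value is a limit of the assay, not a number.

Compound 3 `CCn1ccc2cc(C(OC(C)=O)c3cc(OC)c(OC)c(OC)c3)ccc21` has not yet been measured. Its difference from compound 2 is methyl in place of hydrogen on a saturated chain carbon bound to an aromatic nitrogen and, cut one bond further out, this reads as methyl to ethyl. Going by the values given here, no two measured compounds differ in one place only, so the data give no direct measure of this change. This expectation therefore starts from compound 2 at 6.4 nM and rests on the structural change alone.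

A small step toward weaker inhibition is expected in this assay and is estimated as a 2.2-fold higher number from compound 2 to compound 3 (0.34 log units; beyond the scatter) for this change. A large loss is not expected. In this assay the estimate for compound 3 is 14 nM with an expected range of 4 nM to 60 nM around it.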

Compound 3, half-maximal inhibitory concentration: > 1000 nM
Compound 3: a limit, no number (the forecaster's own chance of this, stated with the estimate: 3%); middle value at least 71-fold (1.85 log units) away from the limit.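

In this assay, methyl in place of hydrogen on a saturated chain carbon bound to an aromatic nitrogen, which reads as methyl to ethyl, gives an at least 150-fold higher number from compound 2 to compound 3 (2.19 log units; beyond the scatter), so this position does not take the change without a large loss in this pair. From the compounds shown here alone, compound 3 gives > 1000 nM, which is a limit of the assay and not a number, so the full size of the step stays unknown: the limit of > 1000 nM in this assay, at which 2 of the 3 values shown sit. Before this result the series held a single number, at compound 2, and no readable step, whereas this pair now shows that the methyl to ethyl change alone is enough to carry compound 2 to the limit.

Going by these compounds, the step from compound 1 to compound 3, acetyl in place of hydrogen on an oxygen on a saturated carbon, cannot be read, since both of its ends are limits, so the part played by the acetyl group stays open. Also open, on these data alone, is how a longer chain such as propyl, or a plain hydrogen, would read at this aromatic nitrogen, and so whether the loss begins with ethyl and persists beyond it.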